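Fluoro added to the anilide ring of compound 1

This account rests on a few compounds, and the source may have more. Where it says the series, first, only, none or still open, it means among the compounds named here.

Among the compounds with values here, compound 1 `Cc1cc(=O)n(-c2ccccc2OC(F)(F)F)nc1C(=O)Nc1ccc(Oc2ncnc3sccc23)cc1` is the weaker of the two compounds measured so far in a functional assay on A549 cells (Homo sapiens) for cytotoxicity, read by MTT assay, with a stated time of 72 h; a lower number here means a stronger inhibitor, a higher number a weaker inhibitor: compound 1 gives 15500 nM. Compound 2 `Cc1cc(=O)n(-c2ccc(F)cc2)nc1C(=O)Nc1ccc(Oc2ncnc3sccc23)cc1` differs from it only in the group on the aromatic nitrogen; in this assay compound 2 gives 7050 nM, and a 2.2-fold lower number from compound 1 to compound 2 (0.34 log units; beyond the scatter). Compound 3 `Cc1cc(=O)n(-c2ccccc2OC(F)(F)F)nc1C(=O)Nc1ccc(Oc2ncnc3sccc23)c(F)c1` keeps the 2-(trifluoromethoxy)phenyl group of compound 1 and changes the anilide ring instead: fluoro in place of hydrogen on an aromatic carbon, ortho to a large group and meta to a large group. Within the data shown here, no measured step touches this ring. Among the measured compounds shown here, the single step available, from compound 1 to compound 2, concerns a different part of the molecule and shows only that the series responds modestly to a change there; it gives no direct guide for the anilide ring. A step within the scatter in this assay is therefore expected, in either direction, for a 1.1-fold lower number from compound 1 to compound 3 (0.04 log units; within the scatter). Compound 3 is estimated at 14000 nM, with a range from 6000 nM to 35000 nM.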

Compound 3, half-maximal inhibitory concentration: > 40000 nM
Compound 3 was reported as a limit; the forecaster's own chance of this, stated with the estimate: 15%; at least 2.8-fold (0.45 log units) between middle value and limit.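

Within this assay, the anilide ring, untouched by the earlier step, responds to the smallest of changes: with fluoro in place of hydrogen on an aromatic carbon, ortho to a large group and meta to a large group, the result is an at least 2.5-fold higher number from compound 1 to compound 3 (0.41 log units; beyond the scatter). Within the data shown here, the only earlier step concerned the group on the aromatic nitrogen and ran the other way, a 2.2-fold lower number from compound 1 to compound 2 (0.34 log units; beyond the scatter), so this position is a second place where a single change moves the number beyond the scatter, here towards a weaker inhibitor. For compound 3 the reading is a limit of the assay and not a number: the limit of > 40000 nM in this assay, at which 1 of the 3 values shown sits.

The compounds shown cannot separate an effect specific to fluoro from one shared by other groups on this carbon; chloro, methyl or methoxy there would make that distinction. Also open, as far as these compounds go, is whether the same fluoro on the anilide ring gives a step of the same direction when the 4-fluorophenyl group of compound 2 replaces the 2-(trifluoromethoxy)phenyl group, and the values shown give no cause for the step.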